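From furan to pyrrole: estimating tolerance of compound 3

The source may report more compounds than this note shows. Statements on the series, on what has been measured and on what is new or still open speak of the compounds shown alone.

Within the data shown here, in an ADME assay on MRC5 cells (Homo sapiens) for cytotoxicity, read by MTT assay, with a stated time of 72 h (a lower number here means that less compound is tolerated, a higher number that more compound is tolerated), compound 1 `OC[C@H]1O[C@@H](n2cc(F)c3c(-c4ccoc4)ncnc32)[C@H](O)[C@@H]1O` gives 15400 nM, the lower of the two numbers measured so far. The only close relative measured, compound 2 `OC[C@H]1O[C@@H](n2cc(F)c3c(-c4ccsc4)ncnc32)[C@H](O)[C@@H]1O`, gives 50000 nM. Compound 3 `OC[C@H]1O[C@@H](n2cc(F)c3c(-c4cc[nH]c4)ncnc32)[C@H](O)[C@@H]1O` has not been measured. It keeps the shared core and changes one group on an aromatic carbon: 1H-pyrrol-3-yl in place of furan-3-yl on an aromatic carbon. Among the measured compounds shown here, one measured step bears on this, an exchange of one five-membered aromatic ring for another at the same place: a 3.2-fold higher number from compound 1 to compound 2 (0.51 log units; beyond the scatter). That step is modest, and a single example cannot show which way a different ring will move the number. A step of similar size or smaller is therefore expected in this assay, with no firm direction. The expected step is a 1.0-fold higher number from compound 1 to compound 3 (0.02 log units; within the scatter). For compound 3 the estimated value is 16000 nM, within an expected range of 5000 nM to 50000 nM.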

Compound 3, half-maximal cytotoxic concentration: 48900 nM
For compound 3 the middle estimate is 3.1-fold (0.49 log units) below the measured one; measured number inside the range.
By their numbers in this assay, from the lowest: compound 1; then compounds 3 and 2 (each within the scatter of the next).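

In this assay, 1H-pyrrol-3-yl in place of furan-3-yl gives a 3.2-fold higher number from compound 1 to compound 3 (0.50 log units; beyond the scatter), so a second five-membered aromatic ring now stands clearly above the furan-3-yl compound. Exchanging thiophen-3-yl for 1H-pyrrol-3-yl gives a 1.0-fold lower number from compound 2 to compound 3 (0.01 log units; within the scatter), so these two rings cannot be told apart here, and among the three compounds the furan-3-yl compound alone has the lower number. No supporting measurement is available to explain why furan-3-yl stands apart from the other two rings.

The three compounds cover only five-membered aromatic rings with one hetero atom, joined through the ring's 3-position. As far as these compounds go, it remains open how the number would respond to a six-membered ring such as phenyl, or to an amine or a short alkyl chain on the same aromatic carbon.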